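Methyl to hydrogen on compound 3: expected shift

The source may report more compounds than this note shows. Statements on the series, on what has been measured and on what is new or still open speak of the compounds shown alone.

For the measured compounds named here, compound 3 `Cc1c(C#Cc2ccc(CCC(=O)O)cc2)cc(Cl)nc1Cl` gives 43.7 nM in an in vitro functional assay on 1321-N1 cells for agonist activity at Free fatty acid receptor 1 (Homo sapiens), read by fluorescence, spectrophotometry and calcium flux (on this read-out lower numbers stand for an effect already at smaller amounts and higher numbers for an effect only at larger amounts of compound), the lowest of the three numbers measured so far. Compound 1 `Cc1c(C#Cc2ccc(CCC(=O)O)cc2)ccnc1Cl` gives 135 nM and compound 2 `O=C(O)CCc1ccc(C#Cc2ccnc(Cl)c2)cc1` gives 295 nM in this assay. The step of a 3.1-fold lower number from compound 1 to compound 3 (0.49 log units; beyond the scatter) brings chloro in for hydrogen on an aromatic carbon, and the step of a 2.2-fold higher number from compound 1 to compound 2 (0.34 log units; beyond the scatter) takes a methyl away from an aromatic carbon.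

Compound 4 `O=C(O)CCc1ccc(C#Cc2cc(Cl)nc(Cl)c2)cc1` has not yet been measured. It differs from compound 3 by hydrogen in place of methyl on an aromatic carbon, on a six-membered aromatic ring with 1 nitrogen, ortho to a chloro group, two atoms from the ring nitrogen and para to a chloro group. Going by the values given here, the one measured step of this kind, a 2.2-fold higher number from compound 1 to compound 2 (0.34 log units; beyond the scatter), is a modest loss beyond the scatter, though it was taken on a core lacking the second chloro group, so it is a single precedent only. For compound 4 the expected step is a 2.2-fold higher number from compound 3 to compound 4 (0.34 log units; beyond the scatter) in this assay. Compound 4 is therefore estimated at 95 nM, with a range from 45 nM to 200 nM.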

Compound 4, half-maximal effective concentration: 40.7 nM
Estimate against measurement, compound 4: 2.3-fold (0.37 log units) above; measured number outside the range, below it.
By their numbers in this assay, from the lowest: compounds 4 and 3 (each within the scatter of the next); then compound 1; then compound 2.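

On the core of compound 3, hydrogen in place of methyl gives a 1.1-fold lower number from compound 3 to compound 4 (0.03 log units; within the scatter) in this assay, so the methyl is not needed at this position once the second chloro group is present. This step and the earlier methyl-to-hydrogen step cannot be told apart: the same change on two cores in this assay, a 2.2-fold higher number (0.34 log units; beyond the scatter) from compound 1 to compound 2 and a 1.1-fold lower number (0.03 log units; within the scatter) from compound 3 to compound 4, 2.3-fold (0.37 log units) apart, within the scatter of two such steps

The second chloro group now lowers the number on two cores, with a 7.2-fold lower number from compound 2 to compound 4 (0.86 log units; beyond the scatter) as the new case, and the two gains agree: the same change on two cores in this assay, a 3.1-fold lower number (0.49 log units; beyond the scatter) from compound 1 to compound 3 and a 7.2-fold lower number (0.86 log units; beyond the scatter) from compound 2 to compound 4, 2.3-fold (0.37 log units) apart, within the scatter of two such steps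

Only methyl and hydrogen are shown at this position, so it remains open whether fluoro, ethyl or methoxy there would shift the number. Also open, on these data alone, is whether another group, such as trifluoromethyl or methoxy, could stand in for the second chloro group.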